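The source may report more compounds than this note shows. Statements on the series, on what has been measured and on what is new or still open speak of the compounds shown alone.

Working notes on the benzothiazole amide series. Compound 1 `COc1ccc2nc(NC(=O)c3cn(-c4ccccc4)nc3-c3ccccc3)sc2c1` gives 17500 nM in a functional assay on PC-3 cells (Homo sapiens) for cytotoxicity, read by MTT assay, with a stated time of 72 h; a lower number here means a stronger inhibitor, a higher number a weaker inhibitor. Compound 2 `COc1ccc2nc(NC(=O)c3cn(-c4ccccc4)nc3-c3ccc(Cl)cc3)sc2c1` gives 29300 nM in this assay; the step of a 1.7-fold higher number from compound 1 to compound 2 (0.22 log units; within the scatter) stays within the scatter. Compound 3 `COc1ccc(-c2nn(-c3ccccc3)cc2C(=O)Nc2nc3ccc(F)cc3s2)cc1` gives 4930 nM in this assay, the lowest of the three numbers, beyond the scatter from both compound 1 and compound 2, and therefore the strongest inhibitor measured so far.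

Compound 4 `COc1ccc(-c2nn(-c3ccccc3)cc2C(=O)Nc2nc3ccc(OC)cc3s2)cc1` has not yet been measured. It differs from compound 3 by methoxy in place of fluoro on an aromatic carbon. Among the measured compounds shown here, no measured step bears directly on this exchange: the only step in hand, a 1.7-fold higher number from compound 1 to compound 2 (0.22 log units; within the scatter), concerns chloro in place of hydrogen on an aromatic carbon elsewhere in the molecule and was within the scatter. Compound 1 and compound 2 carry methoxy on the same fused ring system as compound 4, but they differ from compound 3 in more than one place, so their values give no clean read on fluoro against methoxy at that carbon. The expected step is therefore a 1.1-fold higher number from compound 3 to compound 4 (0.05 log units; within the scatter), none beyond the scatter, with wide uncertainty. Compound 4 is estimated at 5500 nM in this assay, with a range from 2000 nM to 16000 nM.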

Compound 4, half-maximal inhibitory concentration: 13500 nM
Compound 4: middle estimate off by 2.5-fold (0.39 log units), on the low side, and the stated range covers the measured number.
By their numbers in this assay, from the lowest: compound 3; then compounds 4, 1 and 2 (each within the scatter of the next, the first and the last beyond it).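

In this assay, the change from 6-fluoro-1,3-benzothiazol-2-yl to 6-methoxy-1,3-benzothiazol-2-yl gives a 2.7-fold higher number from compound 3 to compound 4 (0.44 log units; beyond the scatter), the first single-place read at this aromatic carbon, and here fluoro carries the lower number of the two groups. The second aromatic position, where compound 1 and compound 2 differ, can now be read with a third group: a 2.2-fold lower number from compound 2 to compound 4 (0.34 log units; beyond the scatter) separates methoxy from chloro, whereas a 1.3-fold lower number from compound 1 to compound 4 (0.11 log units; within the scatter) does not separate methoxy from hydrogen. No measurement in hand accounts for either result.

From the compounds shown here alone, whether the preference for fluoro over methoxy at the first position holds with hydrogen or chloro at the second remains open, since the fluoro-methoxy comparison rests on one pair with methoxy at that second position. Among the compounds shown here, also open is how an amine or a trifluoromethyl group at the first position would compare with fluoro and methoxy, and whether any such exchange would give a number clearly lower than the one for compound 3, 4930 nM.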